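Methoxy in place of hydrogen: toxicity of compound 3 expected

The source may hold more compounds than are shown below. What is called first, only, known or untested is meant among the compounds shown, and "the series" means these compounds.

Compound 1, `COc1ccc(-c2cnc(NC(=O)c3cccc(O)c3)n2C)cc1`: in a toxicity assay on THP-1 cells (Homo sapiens) for inhibition (on this read-out lower numbers stand for higher toxicity in this test and higher numbers for lower toxicity in this test), compound 1 gives > 100000 nM, a limit of the assay and not a number.
Compound 2, `COc1ccc(-c2cnc(NC(=O)c3ccccc3)n2C)cc1`: in this assay compound 2 gives > 100000 nM, likewise a limit of the assay.

Compound 2 therefore stands at the limit of this assay, with no exact number known for it. Among the compounds with values here, the only measured step, a step that the two limits leave unreadable from compound 1 to compound 2, cannot be read because the limit of > 100000 nM in this assay, at which 2 of the 2 values shown sit, holds both of its ends. Compound 3, `COc1ccc(-c2cnc(NC(=O)c3cccc(OC)c3)n2C)cc1`, differs from compound 2 by methoxy in place of hydrogen on an aromatic carbon. No readable measured step bears on this change, so no step beyond the scatter is expected in this assay; the step from compound 2 to compound 3 is expected to be a step that the limit leaves unreadable from compound 2 to compound 3. Compound 3 is thus estimated at 150000 nM in this assay, within a range from 50000 nM to 500000 nM, most likely again reported only as a limit.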

Compound 3, half-maximal cytotoxic concentration: > 100000 nM
Compound 3 was reported as a limit (the forecaster's own chance of this, stated with the estimate: 85%); the middle value lies beyond the limit too.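

Within the data shown here, neither the step from compound 2 to compound 3 nor the one from compound 1 to compound 3 can be read, because each pair has both ends at the same limit: the limit of > 100000 nM in this assay, at which 3 of the 3 values shown sit.

The compounds shown leave open whether hydroxy, hydrogen or methoxy at this place makes any difference to toxicity in this assay.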